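This account rests on a few compounds, and the source may have more. Where it says the series, first, only, none or still open, it means among the compounds named here.

Series notes, amide aryl variation. The shared core carries a thiophen-2-yl amide in compound 1 `O=C(NC1CCN(Cc2ccc(OC3CCNCC3)c(Br)c2)CC1)c1cccs1`, a furan-2-yl amide in compound 2 `O=C(NC1CCN(Cc2ccc(OC3CCNCC3)c(Br)c2)CC1)c1ccco1` and a 1-benzothiophen-2-yl amide in compound 3 `O=C(NC1CCN(Cc2ccc(OC3CCNCC3)c(Br)c2)CC1)c1cc2ccccc2s1`. In an assay on HEK293 cells for displacement of a labelled ligand from Urotensin-2 receptor (Homo sapiens), read by fluorescence, with a stated time of 90 min (on this read-out lower numbers stand for stronger inhibition and higher numbers for weaker inhibition), compound 1 gives 130 nM, compound 2 gives 770 nM and compound 3 gives 63 nM. The step of a 5.9-fold higher number from compound 1 to compound 2 (0.77 log units; beyond the scatter) and the step of a 2.1-fold lower number from compound 1 to compound 3 (0.31 log units; beyond the scatter) run in opposite directions, and the step of a 12-fold lower number from compound 2 to compound 3 (1.09 log units; beyond the scatter) is the largest of the three. Compound 3 therefore stands lowest of the three numbers in this assay, beyond the scatter from both others.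

Compound 4 `O=C(NC1CCN(Cc2ccc(OC3CCNCC3)c(Br)c2)CC1)c1cc2cc(Br)ccc2s1` keeps the 1-benzothiophen-2-yl amide of compound 3 and differs by bromo in place of hydrogen on an aromatic carbon; the group enters on an aromatic carbon of the six-membered aromatic ring of carbon only in the fused two-ring system. Going by the values given here, none of the measured steps concerns a bromo in place of hydrogen on that ring; all three change the aromatic ring at the carbonyl carbon itself, so they do not bear directly on this step. Among the compounds with values here, with no guiding step, a move of a 1.3-fold lower number from compound 3 to compound 4 (0.10 log units; within the scatter) in this assay is expected for compound 4, within the scatter of compound 3. Compound 4 is estimated at 50 nM in this assay, with a range of 18 nM to 160 nM.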

Compound 4, half-maximal inhibitory concentration: 86 nM
The estimate for compound 4 lay 1.7-fold (0.24 log units) below the measured number, and the stated range covers the measured number.
By their numbers in this assay, from the lowest: compounds 3, 4 and 1 (each within the scatter of the next, the first and the last beyond it); then compound 2.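

In this assay, going by these compounds alone, bromo in place of hydrogen on the six-membered aromatic ring of carbon only, in the fused two-ring system, leaves the number within the scatter (a 1.4-fold higher number from compound 3 to compound 4 (0.14 log units; within the scatter)), so this ring accepts one added bromine without a change that can be read here, the first information on this ring. The 5-bromo-1-benzothiophen-2-yl amide also stands within the scatter of the thiophen-2-yl amide (a 1.5-fold lower number from compound 1 to compound 4 (0.18 log units; within the scatter)), whereas the gap to the furan-2-yl amide remains beyond it (a 9.0-fold lower number from compound 2 to compound 4 (0.95 log units; beyond the scatter)), and compound 2 therefore still gives the highest number of the four. Nothing given here on the compounds accounts for any of these numbers.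

Going by these compounds, it remains open whether this carbon accepts groups of another kind, such as a methoxy group, an amine or a carboxylic acid, as it accepts bromo. On these data alone, it is equally open whether bromo on another carbon of the same ring would also stay within the scatter of compound 3.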